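The compounds below may be only part of what the source reports. "The series", "measured", "known", "first", "only" and "open" are said of these compounds alone.

Measured so far in an ADME assay on microsomes (Mus musculus) for metabolic stability; a higher number here means faster removal of the compound, a lower number slower removal:

- compound 1 `CNC(=O)[C@@H]1CCCN1S(=O)(=O)c1ccc(Cl)c(COc2cccc3c(-n4ccnc4)cc(C)nc23)c1Cl`: 267 mL/min/kg
- compound 2 `CNC(=O)[C@@H]1CCCN1S(=O)(=O)c1cccc(COc2cccc3c(C(F)(F)F)cc(C)nc23)c1`: 767 mL/min/kg
- compound 3 `Cc1cc(C(F)(F)F)c2cccc(OCc3c(Cl)ccc(S(=O)(=O)N4CCC[C@H]4C(=O)O)c3Cl)c2n1`: 13.3 mL/min/kg

Compound 3 has the lowest number of the three, and both compound 1 and compound 2 stand beyond the scatter above it. Only compound 3 carries 2-carboxypyrrolidin-1-yl.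

Compound 4 `Cc1cc(C(F)(F)F)c2cccc(OCc3c(Cl)ccc(S(=O)(=O)N4CC[C@@H](N(C)C)C4)c3Cl)c2n1` keeps the rest of compound 3 and has 3-(dimethylamino)pyrrolidin-1-yl in place of 2-carboxypyrrolidin-1-yl on a sulfonyl sulfur.

Within the data shown here, no measured pair isolates this change, and the three compounds cannot separate the carboxy group from their other differences. Any expectation in this assay therefore rests on the values alone and is loose. Without the 2-carboxypyrrolidin-1-yl group, compound 1 gives 267 mL/min/kg and compound 2 gives 767 mL/min/kg, whereas compound 3 with it gives 13.3 mL/min/kg. On that basis, a rise beyond the scatter is expected, with compound 4 landing nearer compound 1 than compound 3. The estimated size of this rise is a 15-fold higher number from compound 3 to compound 4 (1.18 log units; beyond the scatter). For compound 4 the expected value is 200 mL/min/kg, with an estimated range of 70 mL/min/kg to 550 mL/min/kg.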

Compound 4, clearance: 867 mL/min/kg
Beside the measured number, compound 4's estimate is 4.3-fold (0.64 log units) below it; the whole stated range lies below it.
By their numbers in this assay, from the lowest: compound 3; then compound 1; then compounds 2 and 4 (each within the scatter of the next).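

With the rest of compound 3 kept, the swap of 2-carboxypyrrolidin-1-yl for 3-(dimethylamino)pyrrolidin-1-yl on a sulfonyl sulfur gives, in this assay, a 65-fold higher number from compound 3 to compound 4 (1.81 log units; beyond the scatter) and thus a large change that belongs to this one place. The earlier compounds shown here differed in several places at once and could not separate the group on the sulfonyl sulfur from their other differences, whereas this pair shows that the low number of compound 3 does not survive this change on an otherwise unchanged core. No measurement at hand bears on the reason for the step.

The step still joins several changes in one: the carboxy group leaves, the dimethylamino group enters, and the substituent moves from the 2-position to the 3-position of the pyrrolidine, so the pair cannot say which of these carries it. From the compounds shown here alone, an unsubstituted pyrrolidin-1-yl and a 3-carboxypyrrolidin-1-yl on the same sulfonyl sulfur would separate these, and whether the low number needs a carboxylic acid at all remains open.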